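The compounds below may be only part of what the source reports. "The series", "measured", "known", "first", "only" and "open" are said of these compounds alone.

Compound 3, with the structure `CN1CCC[C@H]1[C@H]1COc2ccc(Br)cc2O1`, has the lowest number of the three compounds measured in an assay on Cerebral cortex (strain Sprague-Dawley) for displacement of a labelled ligand from Neuronal acetylcholine receptor; alpha4/beta2 (Rattus norvegicus) (a lower number here means a stronger inhibitor, a higher number a weaker inhibitor), at 3000 nM. Its nearest neighbour is compound 2, `CN1CCC[C@H]1[C@@H]1COc2ccc(Br)cc2O1`, which gives 8100 nM; the furthest is compound 1, `CN1CCC[C@H]1[C@H]1COc2ccc(CO)cc2O1`, which gives 9500 nM. The step of a 2.7-fold lower number from compound 2 to compound 3 (0.43 log units; beyond the scatter) rests on (the fact that compounds 2 and 3 differ only in the configuration as drawn). The step of a 3.2-fold lower number from compound 1 to compound 3 (0.50 log units; beyond the scatter) is the only one that alters the substituent on the aromatic carbon.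

Compound 4, `COc1ccc2c(c1)O[C@@H]([C@@H]1CCCN1C)CO2`, differs from compound 3 in one place: methoxy in place of bromo on an aromatic carbon. For the measured compounds named here, no measured step exchanges bromo for methoxy, so the expectation draws on the step from compound 1 to compound 3, where a hydroxymethyl in the same place gave the higher number. A methoxy carries one hydrogen-bond acceptor where the bromo carries none, and the hydroxymethyl of compound 1 also carried an acceptor; on that likeness a somewhat higher number than that of compound 3 is expected, though a shift that stays within the scatter is also possible.

Compound 4 is therefore estimated at 5000 nM in this assay, with a range of 2000 nM to 14000 nM. The expected step is a 1.7-fold higher number from compound 3 to compound 4 (0.22 log units; within the scatter).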

Compound 4, inhibition constant: 4200 nM
Estimate against measurement, compound 4: 1.2-fold (0.08 log units) above; measured number inside the range.
By their numbers in this assay, from the lowest: compounds 3, 4, 2 and 1 (each within the scatter of the next, the first and the last beyond it).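

In this assay, putting methoxy in place of bromo on this aromatic carbon gives a 1.4-fold higher number from compound 3 to compound 4 (0.15 log units; within the scatter), so the two groups cannot be told apart here, even though only the methoxy is counted with a hydrogen-bond acceptor. For the compounds shown here, the same position does separate methoxy from hydroxymethyl, with a 2.3-fold lower number from compound 1 to compound 4 (0.35 log units; beyond the scatter), and this is what the earlier compounds could not show: the step from hydroxymethyl to bromo alone left open whether any group with a hydrogen-bond acceptor at this place would share the higher number of compound 1. Among the three groups seen here, that higher number belongs to the hydroxymethyl alone, and the methoxy does not share it.

As far as these compounds go, how an amine, a carboxylic acid or a longer chain such as ethoxy would behave on this aromatic carbon stays open, as does whether the methoxy series would answer to configuration at the saturated ring carbon as the bromo pair of compound 2 and compound 3 does. Nothing available bears on why methoxy and bromo stand so close while hydroxymethyl stands apart.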